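Chain additions at the amine nitrogen: permeability notes

A few compounds are considered here, and "the series" means these few. Any claim that something is new, unique, unknown or untested is made for them only; others in the source may bear on it.

Measured compounds:
compound 1 `NCCCCN(C[C@H]1Cc2ncccc2CN1)[C@H]1CCCc2cccnc21`: 14 nm/s
compound 2 `CN(C[C@H]1Cc2ncccc2CN1)[C@H]1CCCc2cccnc21`: 1300 nm/s
compound 3 `NC(=O)NC/C=C/CN(C[C@H]1Cc2ncccc2CN1)[C@H]1CCCc2cccnc21`: 2 nm/s

In an ADME assay for permeability, using PAMPA, with a stated time of 4 h, at pH 7.4 (on this read-out higher numbers stand for higher permeability and lower numbers for lower permeability), compound 2 stands highest of the three numbers, with compound 1 nearest and compound 3 furthest. Both measured steps away from compound 2 put a chain in place of a hydrogen on the saturated chain carbon bound to the amine nitrogen, and both lowered the number: a 93-fold higher number from compound 1 to compound 2 (1.97 log units; beyond the scatter) read in reverse, and a 650-fold lower number from compound 2 to compound 3 (2.81 log units; beyond the scatter). Between the two chains the difference is a 7.0-fold lower number from compound 1 to compound 3 (0.85 log units; beyond the scatter).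

Compound 4 `c1cnc2c(c1)CN[C@@H](CN(CCCCNC1COC1)[C@H]1CCCc3cccnc31)C2` differs from compound 2 by a group of 8 heavy atoms (6 carbon, 1 nitrogen, 1 oxygen; one four-membered non-aromatic ring with 1 hetero atom) in place of a hydrogen atom, on a saturated chain carbon bound to an amine nitrogen. The entering group is again a chain on the same saturated carbon, ending in a nitrogen-bearing fragment, so the steps to compound 1 and compound 3 bear on it, and a large drop from compound 2 is expected rather than no change. The step is expected to be a 43-fold lower number from compound 2 to compound 4 (1.64 log units; beyond the scatter), in the lower direction. Compound 4 is therefore estimated at 30 nm/s, with a range from 5 nm/s to 150 nm/s.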

Compound 4, apparent permeability: 300 nm/s
Estimate against measurement, compound 4: 10-fold (1.00 log units) below; measured number outside the range, above it.
By their numbers in this assay, from the lowest: compound 3; then compound 1; then compound 4; then compound 2.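

With oxetan-3-yl in place of hydrogen on an amine nitrogen, this assay gives a 21-fold higher number from compound 1 to compound 4 (1.33 log units; beyond the scatter), so the group on the chain's amine nitrogen can change the number substantially while the rest of compound 1 stays the same. Going by these compounds alone, a chain at this position therefore need not cost as much as the earlier steps suggested: the step away from the hydrogen is now modest, a 4.3-fold lower number from compound 2 to compound 4 (0.64 log units; beyond the scatter), and the step between the two capped chains is large, a 150-fold higher number from compound 3 to compound 4 (2.18 log units; beyond the scatter). No measurement available here gives a reason for these differences.

On these data alone, whether a cyclobutyl or a methyl on that amine nitrogen would give a number like that of compound 4 stays open. So does whether oxetan-3-yl would act the same way on a shorter chain.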